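The source may hold more compounds than are shown below. What is called first, only, known or untested is meant among the compounds shown, and "the series" means these compounds.

Three compounds built on one shared core have been examined in a functional assay on DU-145 cells (Homo sapiens) for cytotoxicity, read by CCK-8 assay and cell counting, with a stated time of 2 days; a lower number here means a stronger inhibitor, a higher number a weaker inhibitor. For compound 1 `Oc1cccc(-c2cc(-c3cccnc3)nc(-c3cccc(Cl)c3)c2)c1` the result in this assay is "not determined" (no result reported). Compound 2 `Oc1cccc(-c2cc(-c3ccc(Cl)cc3)nc(-c3cccs3)c2)c1` gives 11600 nM. Within the data shown here, compound 3 `Oc1cccc(-c2cc(-c3cccs3)nc(-c3ccccc3Cl)c2)c1` gives 1700 nM, and the only single-point step among the measured compounds leads to it: a 6.8-fold lower number from compound 2 to compound 3 (0.83 log units; beyond the scatter). Compound 3 therefore holds the lower of the two reported numbers; its nearest measured neighbour is compound 2, and that gap lies beyond the scatter.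

Compound 4 `Oc1cccc(-c2cc(-c3cccc(Cl)c3)nc(-c3cccs3)c2)c1` differs from compound 3 in one place: 3-chlorophenyl in place of 2-chlorophenyl on an aromatic carbon. Among the measured compounds shown here, the only measured step that bears on this is the one from compound 2 to compound 3, which shows that moving the chlorine on that phenyl ring can shift the number by more than the scatter. For the measured compounds named here, no measured compound carries a 3-chlorophenyl group, so its own effect is unknown. The number for compound 4 is expected to fall between the two reported values, which corresponds to an expected step of a 2.4-fold higher number from compound 3 to compound 4 (0.37 log units; beyond the scatter). For compound 4 the estimate in this assay is 4000 nM, with a range from 1500 nM to 11000 nM.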

Compound 4, half-maximal inhibitory concentration: 2650 nM
Compound 4: middle estimate off by 1.5-fold (0.18 log units), on the high side; measured number inside the range.
By their numbers in this assay, from the lowest: compounds 3 and 4 (each within the scatter of the next); then compound 2.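

In this assay the step of a 1.6-fold higher number from compound 3 to compound 4 (0.19 log units; within the scatter) lies within the scatter, so at this position on the shared core, next to the ring nitrogen, 2-chlorophenyl and 3-chlorophenyl cannot be told apart. The step of a 4.4-fold lower number from compound 2 to compound 4 (0.64 log units; beyond the scatter) lies beyond the scatter, and with it compound 2, the 4-chlorophenyl member, now stands apart from both other measured compounds rather than from compound 3 alone; among these three, the change that registers is the one to or from 4-chlorophenyl, not every shift of the chlorine. Nothing measured here explains why these three chlorine placements compare as they do.

Whether the chlorine itself matters stays open, since the compounds shown offer no comparison with a plain phenyl group or with another group, such as a methoxy group or an amine, on that ring. From the compounds shown here alone, all three numbers also come from compounds carrying the thiophen-2-yl group, and compound 1 has no number, so steps to it cannot be read and it remains unknown whether the same comparison holds with a different partner.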